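A few compounds are considered here, and "the series" means these few. Any claim that something is new, unique, unknown or untested is made for them only; others in the source may bear on it.

Measured so far:
compound 1 `Nc1ccccc1NC(=O)/C=C/c1ccc(Cn2cnc3c(NCc4ccccc4)nc(Cl)nc32)cc1`: 17.4%
compound 2 `Nc1ccccc1NC(=O)c1ccc(CNc2nc(Cl)nc3c2ncn3Cc2ccccc2)cc1`: 11.5%

In a functional assay on HCT-116 cells (Homo sapiens) for antiproliferative activity, read by CCK-8 assay, with a stated time of 72 h, tested at 8 uM (on this read-out lower numbers stand for a weaker effect and higher numbers for a stronger effect at the one concentration tested), compound 2 gives 11.5% and compound 1 gives 17.4%; the two numbers lie within the scatter of each other, so nothing separates them. Compound 3 `CCC(C)n1cnc2c(NCc3ccc(C(=O)Nc4ccccc4N)cc3)nc(Cl)nc21` departs from compound 2 by sec-butyl in place of benzyl on an aromatic nitrogen. Within the data shown here, no measured pair shows the effect of such a change here, so for the step from compound 2 to compound 3 in this assay no movement beyond the scatter is expected in either direction. Compound 3 is therefore estimated at 12%, between 3% and 25%, an expected step of a number 0.5 percentage points higher from compound 2 to compound 3 (within the scatter).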

Compound 3, a percentage reported as inhibition, at one concentration (the size of the read-out at that concentration, not a potency): 75.1%
Compound 3: middle estimate off by 63.1 percentage points, on the low side, outside the stated range (above it).
By their numbers in this assay, from the lowest: compounds 2 and 1 (each within the scatter of the next); then compound 3.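

In this assay, the group on the aromatic nitrogen of the five-membered ring proves to be a sensitive position: sec-butyl in place of benzyl gives a number 63.6 percentage points higher from compound 2 to compound 3 (beyond the scatter), a large step. Among these compounds, no earlier pair tested this position, and this change replaces a group carrying a six-membered aromatic ring with a ringless branched chain. Nothing available bears on the reason for this step.

Open, as far as these compounds go, is whether the ring's absence or the chain's branching goes with the higher number. Isopropyl, straight-chain butyl and cyclopentyl on the same nitrogen would separate these readings.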